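Swapping Trifluoromethoxy for Trifluoromethyl in Cytotoxicity Testing

This account rests on a few compounds, and the source may have more. Where it says the series, first, only, none or still open, it means among the compounds named here.

Of the compounds shown here, three have so far been tested in an ADME assay on Vero cells (Chlorocebus sabaeus) for cytotoxicity, with a stated time of 72 h; on this read-out higher numbers stand for weaker inhibition and lower numbers for stronger inhibition. Compound 1 `O=[N+]([O-])c1cn2c(n1)OCC(COc1ccc(-c3ccc(OC(F)(F)F)cc3)cc1)C2` carries a trifluoromethoxy group on its outer ring. In this assay compound 1 gives > 128000 nM, which is a limit of the assay rather than a number. Compound 2 `O=[N+]([O-])c1cn2c(n1)OCC(COc1ccc(-c3ccc(C(F)(F)F)cc3)cc1)C2` differs from compound 1 by trifluoromethyl in place of trifluoromethoxy on an aromatic carbon. Compound 2 likewise reaches only a limit, > 128000 nM. The step that the two limits leave unreadable from compound 1 to compound 2. Compound 3 `O=[N+]([O-])c1cn2c(n1)OCC(COc1ccc(-c3ccc(OC(F)(F)F)cc3)cn1)C2` keeps the trifluoromethoxy group but sits on a different core; the difference between the cores of compound 1 and compound 3 is not broken down here. Compound 3 also gives only a limit, > 128000 nM. All three values share one point: the limit of > 128000 nM in this assay, at which 3 of the 3 values shown sit.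

Compound 4 `O=[N+]([O-])c1cn2c(n1)OCC(COc1ccc(-c3ccc(C(F)(F)F)cc3)cn1)C2` has not yet been tested. It differs from compound 3 by trifluoromethyl in place of trifluoromethoxy on an aromatic carbon, the same change as from compound 1 to compound 2, at the same place. Because the earlier change left both values at the limit of > 128000 nM in this assay, at which 3 of the 3 values shown sit, compound 4 is expected to show the step that the limit leaves unreadable from compound 3 to compound 4. The estimate for compound 4 is 150000 nM, between 100000 nM and 300000 nM, most likely again only a limit.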

Compound 4, half-maximal inhibitory concentration: > 128000 nM
Compound 4 was reported as a limit; the forecaster's own chance of this, stated with the estimate: 85%; the middle value is on the limit's open side.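

The size of the swap from trifluoromethoxy to trifluoromethyl cannot be read from compound 3 to compound 4, nor from compound 1 to compound 2, because all four compounds share one limit: the limit of > 128000 nM in this assay, at which 4 of the 4 values shown sit.

The compounds shown leave open what actual value any of them would give in this assay, and whether this swap changes that value.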